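Trifluoromethoxy in Place of (Trifluoromethyl)sulfanyl on the Shared Core

The source may hold more compounds than are shown below. What is called first, only, known or untested is meant among the compounds shown, and "the series" means these compounds.

Three compounds share one core and differ only in the group on the outer ring. Compound 1 `COc1ccc(NC(=O)Nc2cc(C)nc3ccccc23)cc1` carries a methoxy there. In an ADME assay on Raji cells (Homo sapiens) for cytotoxicity, with a stated time of 72 h (a higher number here means that more compound is needed for the effect, a lower number that less compound is needed), compound 1 gives > 25000 nM, which is a limit of the assay, not a number. Compound 2 `Cc1cc(NC(=O)Nc2ccc(N(C)C)cc2)c2ccccc2n1` carries a dimethylamino. In this assay compound 2 gives > 25000 nM, again a limit. Among the measured compounds shown here, compound 3 `Cc1cc(NC(=O)Nc2ccc(SC(F)(F)F)cc2)c2ccccc2n1` carries a (trifluoromethyl)sulfanyl and is the only compound with a number: in this assay compound 3 gives 10000 nM. The steps of an at least 2.5-fold lower number from compound 1 to compound 3 (0.39 log units; beyond the scatter) and an at least 2.5-fold lower number from compound 2 to compound 3 (0.39 log units; beyond the scatter) can be read only as lower bounds because of the limit of > 25000 nM in this assay, at which 2 of the 3 values shown sit; the step that the two limits leave unreadable from compound 1 to compound 2 cannot be read at all.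

Compound 4 `Cc1cc(NC(=O)Nc2ccc(OC(F)(F)F)cc2)c2ccccc2n1` differs from compound 3 by trifluoromethoxy in place of (trifluoromethyl)sulfanyl on an aromatic carbon. For the measured compounds named here, no measured step tests this change: all three swap a methoxy or dimethylamino, not one fluorinated group for another. With no guidance from the measured steps, the expected step is one within the scatter, a 1.2-fold higher number from compound 3 to compound 4 (0.08 log units; within the scatter). Compound 4 is therefore estimated at 12000 nM, with a range from 5000 nM to 25000 nM.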

Compound 4, half-maximal effective concentration: 10000 nM
Beside the measured number, compound 4's estimate is 1.2-fold (0.08 log units) above it; the range from low to high includes it.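

In this assay, exchanging one fluorinated group for the other at this position, para to a large group, gives no change at the digits printed from compound 3 to compound 4 (within the scatter), so here the trifluoromethoxy and the (trifluoromethyl)sulfanyl cannot be told apart. Among the compounds shown here, until now only one fluorinated group had a number, whereas a second now also stands apart from the two non-fluorinated groups, with an at least 2.5-fold lower number from compound 2 to compound 4 (0.39 log units; beyond the scatter) and an at least 2.5-fold lower number from compound 1 to compound 4 (0.39 log units; beyond the scatter). These two steps can be read only as lower bounds because each starts from a limit: the limit of > 25000 nM in this assay, at which 2 of the 4 values shown sit.

From the compounds shown here alone, the true distance of compound 1 and compound 2 from the fluorinated compounds stays open, as does the step between compound 1 and compound 2, which cannot be read. Also open, going by these compounds, is whether a fluorine-free group such as a chlorine atom, a carboxylic acid or a longer alkyl chain at this position would give a number in this assay at all.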